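The source may hold more compounds than are shown below. What is called first, only, known or untested is meant among the compounds shown, and "the series" means these compounds.

Working notes on the shared core of compound 3 `CN1CCN(CC(=O)Nc2ccc(-c3nc4cc(Cl)c(Cl)cc4[nH]3)cc2)CC1` and its relatives. In an ADME assay on MDBK cells (Bos taurus) for cytotoxicity, read by MTT assay, with a stated time of 96 h (a lower number here means that less compound is tolerated, a higher number that more compound is tolerated), compound 3 gives 90000 nM, the highest of the three numbers recorded. The nearest is compound 1 `O=C(CN1CCCCC1)Nc1ccc(-c2nc3cc(Cl)c(Cl)cc3[nH]2)cc1`, which in this assay gives 45000 nM; the two numbers lie within the scatter of each other. The furthest is compound 2 `COc1ccc(-c2nc3cc(Cl)c(Cl)cc3[nH]2)cc1`, which in this assay gives 2500 nM, a gap that lies beyond the scatter.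

The change from compound 3 to compound 4 `CC(=O)Nc1ccc(-c2nc3cc(Cl)c(Cl)cc3[nH]2)cc1` is hydrogen in place of 4-methylpiperazin-1-yl on a saturated chain carbon bound to a carbonyl carbon. For the measured compounds named here, only one measured step touches the same position: a 2.0-fold higher number from compound 1 to compound 3 (0.30 log units; within the scatter), an exchange of one saturated ring for another that left the number within the scatter. Going by the values given here, no measured step removes the whole amine-bearing chain and leaves a bare methyl on the carbonyl carbon, so the available steps give no direct guide. The values of compound 3 and compound 2 show that the larger amide-bearing compounds sit well above the small methoxy compound in this assay, and compound 4 is structurally between them.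

For compound 4 the expected step is therefore a 3.6-fold lower number from compound 3 to compound 4 (0.56 log units; beyond the scatter), toward a lower number. The estimated value for compound 4 in this assay is 25000 nM, with a range from 6000 nM to 90000 nM.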

Compound 4, half-maximal cytotoxic concentration: 58000 nM
For compound 4 the middle estimate is 2.3-fold (0.37 log units) below the measured one; measured number inside the range.
By their numbers in this assay, from the lowest: compound 2; then compounds 1, 4 and 3 (each within the scatter of the next).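

With hydrogen in place of 4-methylpiperazin-1-yl on a saturated chain carbon bound to a carbonyl carbon, this assay gives a step inside the scatter (a 1.6-fold lower number from compound 3 to compound 4 (0.19 log units; within the scatter)), and hydrogen in place of piperidin-1-yl gives the same kind of result (a 1.3-fold higher number from compound 1 to compound 4 (0.11 log units; within the scatter)), so across compounds 1, 3 and 4 the number shows no dependence on the ring at this position. The large gap to compound 2 therefore does not require either ring, since acetamido in place of methoxy on an aromatic carbon alone accounts for a step beyond the scatter (a 23-fold higher number from compound 2 to compound 4 (1.37 log units; beyond the scatter)), a separation that compounds 1, 2 and 3 could not make. No measurement at hand explains either the flat steps at the chain carbon or the large step at the aromatic carbon.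

Still open, going by these compounds, is whether a carboxylic acid or a longer chain on the saturated chain carbon would stay within the scatter of compound 4 as the two rings do. Also open, on these data alone, is whether the large step belongs to acetamido in particular, or whether an amine on the aromatic carbon would give a number nearer compound 4 than compound 2.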